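Shortening the chain on a bicyclic lactone core

The source may hold more compounds than are shown below. What is called first, only, known or untested is meant among the compounds shown, and "the series" means these compounds.

Compound 2 `CC(C)(C)OC(=O)NCCCC[C@H]1N=C2C[C@H]3C[C@H](C3(C)C)[C@@]2(C)OC1=O` was tested in a functional assay on MCF7 cells (Homo sapiens) for antiproliferative activity, read by sulforhodamine B assay, with a stated time of 48 h (on this read-out lower numbers stand for stronger inhibition and higher numbers for weaker inhibition), and gives 15300 nM. Among the measured compounds shown here, that is the higher of the two numbers measured so far: compound 1 `CC(C)(C)OC(=O)NCCC[C@@H]1N=C2C[C@@H]3C[C@@H](C3(C)C)[C@]2(C)OC1=O` gives 6300 nM in this assay, a gap that lies beyond the usual scatter, so compound 2 is the weaker of the two measured compounds on this read-out.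

The next compound, compound 3 `CC(C)(C)OC(=O)NCCC[C@H]1N=C2C[C@H]3C[C@H](C3(C)C)[C@@]2(C)OC1=O`, has not yet been measured. It differs from compound 2 by one change: (tert-butoxycarbonyl)amino in place of ((tert-butoxycarbonyl)amino)methyl on a saturated chain carbon, three bonds along the chain from a saturated ring carbon. In plain words, the chain carrying the carbamate is one carbon shorter, so the protected amine sits closer to the core, while everything else, including the core itself and its stereochemistry, stays as in compound 2.

For the measured compounds named here, no measured pair in this set tests a step of exactly this kind, so there is no direct precedent to lean on. A change of one chain carbon is usually a small step. The expectation is that a 1.5-fold lower number from compound 2 to compound 3 (0.18 log units; within the scatter) will be modest, leaning toward a lower number but not clearly beyond the scatter. For compound 3 in this assay the estimated value is 10000 nM, with a range from 4000 nM to 25000 nM.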

Compound 3, half-maximal inhibitory concentration: 56000 nM
Beside the measured number, compound 3's estimate is 5.6-fold (0.75 log units) below it; measured number above the stated range.
By their numbers in this assay, from the lowest: compound 1; then compound 2; then compound 3.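

One chain carbon is not a small step at this position: in this assay, replacing ((tert-butoxycarbonyl)amino)methyl with (tert-butoxycarbonyl)amino gives a 3.7-fold higher number from compound 2 to compound 3 (0.56 log units; beyond the scatter). With the configuration drawn in compound 3, then, the shorter chain weakens the antiproliferative effect, and compound 3 is the weakest of the three. The other step, an 8.9-fold higher number from compound 1 to compound 3 (0.95 log units; beyond the scatter), is also beyond the scatter and can be traced to the drawn configuration alone, because nothing else separates the pair: the fact that compounds 1 and 3 differ only in the configuration as drawn

The compounds shown leave open how chain length and configuration work together, as compound 1 and compound 2 differ in both and cannot give a clean reading of either. As far as these compounds go, it also remains unknown whether a free amine at the chain end, or a longer chain, would respond as sharply as the carbamate-bearing chains do here.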